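Side-chain variation at the amino-acid carbon, oral tail flick

The source may hold more compounds than are shown below. What is called first, only, known or untested is meant among the compounds shown, and "the series" means these compounds.

Measured so far:
compound 1 `CC(C)[C@H](NC(=O)CN(c1ncnc2c1ncn2C1CCCCO1)C1CC1)C(=O)OCc1ccccc1` — 21.8%
compound 2 `NC(=O)CC[C@H](NC(=O)CN(c1nc(Cl)nc2[nH]cnc12)C1CC1)C(=O)OCc1ccccc1` — 30.8%
compound 3 `C[C@@H](O)[C@H](NC(=O)CN(c1nc(Cl)nc2[nH]cnc12)C1CC1)C(=O)OCc1ccccc1` — 21.9%

In a functional assay on the whole organism (Tail, strain ICR) with Mus musculus as the target, in the tail flick test, with a stated time of 30 min, at a dose of 25 umol/kg by the oral route (a lower number here means a weaker effect, a higher number a stronger effect of the compound at the dose given), compound 1 gives 21.8%. Its number sits at the low end of the three, but its gaps to compound 3 and to compound 2 are both within the scatter, so the three measured compounds cannot be separated in this assay.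

Compound 4 `CC(C)C[C@H](NC(=O)CN(c1ncnc2c1ncn2C1CCCCO1)C1CC1)C(=O)OCc1ccccc1` differs from compound 1 in one place: isobutyl in place of isopropyl on a saturated chain carbon bound to an amide-type nitrogen and a carbonyl carbon. Among the compounds with values here, the only measured step at that place is the change from compound 2 to compound 3, on the core of compound 2 rather than that of compound 1, with a number 8.9 percentage points lower from compound 2 to compound 3 (within the scatter). Within the data shown here, no measured step exchanges isopropyl for isobutyl, and no step on the core of compound 1 exists at all.

Among the measured compounds shown here, with the one step at this place within the scatter and the whole set flat, no step beyond the scatter is expected from compound 1 to compound 4, so the estimate is a number 2.2 percentage points higher from compound 1 to compound 4 (within the scatter). Compound 4 is therefore expected to give about 24% in this assay, within the range 10% to 40%.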

Compound 4, a percentage reported as activity, at one dose (the size of the read-out at that dose, not a potency): 26.2%
Compound 4: the middle estimate sits 2.2 percentage points below what was measured, within the range that was stated.
By their numbers in this assay, from the lowest: compounds 1, 3, 4 and 2 (each within the scatter of the next).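

Within the data shown here, on the core of compound 1, isobutyl in place of isopropyl on a saturated chain carbon bound to an amide-type nitrogen and a carbonyl carbon gives the first step at this place on that core in this assay (a number 4.4 percentage points higher from compound 1 to compound 4 (within the scatter)). With the earlier step on the core of compound 2 (a number 8.9 percentage points lower from compound 2 to compound 3 (within the scatter)), both side-chain exchanges read so far, one between two hydrocarbon chains and one between chains carrying other groups, stay within the scatter, and no listed step goes against this. Nothing available explains the result.

As far as these compounds go, whether a carboxylic acid, an amine or a benzyl group at this place would move the read-out beyond the scatter remains open. From the compounds shown here alone, it also remains open whether any such step would carry over between the core of compound 1 and the core of compound 2.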